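A few compounds are considered here, and "the series" means these few. Any claim that something is new, unique, unknown or untested is made for them only; others in the source may bear on it.

Working notes on the side chain of the shared core. In a functional assay on HL-60 cells (Homo sapiens) for antiproliferative activity, read by MTT assay, with a stated time of 72 h (on this read-out higher numbers stand for weaker inhibition and lower numbers for stronger inhibition), compound 1 (`C/C=C1/[C@H](O[C@@H]2O[C@H](CO)[C@@H](O)[C@H](O)[C@H]2O)OC=C(C(=O)OC)[C@H]1CC(=O)OCCC1CCCCC1`) reads 480 nM while compound 2 (`C/C=C1/[C@H](O[C@@H]2O[C@H](CO)[C@@H](O)[C@H](O)[C@H]2O)OC=C(C(=O)OC)[C@H]1CC(=O)OCCC(C)C`) reads 9830 nM and so holds the higher of the two numbers. The change phenyl in place of isopropyl on a saturated chain carbon, two bonds along the chain from an oxygen next to a carbonyl group leads from compound 2 to compound 3 (`C/C=C1/[C@H](O[C@@H]2O[C@H](CO)[C@@H](O)[C@H](O)[C@H]2O)OC=C(C(=O)OC)[C@H]1CC(=O)OCCc1ccccc1`), not yet measured, and puts phenyl in place of isopropyl on a saturated chain carbon, two bonds along the chain from an oxygen next to a carbonyl group. Within the data shown here, the only measured step at this place is a 20-fold higher number from compound 1 to compound 2 (1.31 log units; beyond the scatter) (large, beyond the scatter), where isopropyl replaced cyclohexyl. Phenyl also restores a ring, but an aromatic one, and no measurement yet compares the two rings. With compound 1 at 480 nM as the only ring-bearing reference, a large move to a lower number than compound 2 is expected in this assay, probably short of that full step. The expected move is a 7.6-fold lower number from compound 2 to compound 3 (0.88 log units; beyond the scatter) on this estimate. For compound 3 the estimate is 1300 nM within an expected range of 350 nM to 4500 nM for now.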

Compound 3, half-maximal inhibitory concentration: 10300 nM
The estimate for compound 3 lay 7.9-fold (0.90 log units) below the measured number, and the stated range ends below it.
By their numbers in this assay, from the lowest: compound 1; then compounds 2 and 3 (each within the scatter of the next).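

In this assay, phenyl in place of isopropyl gives a 1.0-fold higher number from compound 2 to compound 3 (0.02 log units; within the scatter) and so does not separate the aromatic ring from the open-chain group at this position. Phenyl in place of cyclohexyl gives a 21-fold higher number from compound 1 to compound 3 (1.33 log units; beyond the scatter) and shows that at this position, among these three compounds, a ring alone does not go with the lower number: only the cyclohexyl of compound 1 stands apart. Nothing at hand accounts for the difference between the two rings.

Whether this standing is particular to cyclohexyl stays open, since the compounds shown include neither a smaller saturated ring such as cyclopentyl nor a longer chain carrying the cyclohexyl. On these data alone, how a phenyl bearing an amine or a carboxylic acid would read at this position also remains open.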